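This account rests on a few compounds, and the source may have more. Where it says the series, first, only, none or still open, it means among the compounds named here.

Of the compounds shown here, three have been measured here for their ability to switch on a nuclear receptor, read through a luciferase reporter. Compound 1 `CCc1nc2sccn2c1/C=N/OCc1ccc(Cl)c(Cl)c1` gives 2600 nM in an assay on HepG2 cells for agonist activity at nuclear receptor subfamily 1 group I member 3 (Homo sapiens), read by a luciferase reporter, with a stated time of 23 h; a higher number here means that more compound is needed for the effect, a lower number that less compound is needed; this is the second highest of the three numbers. Its nearest neighbour is compound 2 `N#Cc1ccc(-c2nc3sccn3c2/C=N/OCc2ccc(Cl)c(Cl)c2)cc1`, which gives 3400 nM in this assay, and the furthest is compound 3 `C(=N/OCc1ccccc1)\c1c(-c2ccc3ccccc3c2)nc2occn12`, which gives 840 nM in this assay, a number beyond the scatter from that of compound 1.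

Compound 4 `CC(C)(C)c1ccc(-c2nc3sccn3c2/C=N/OCc2ccc(Cl)c(Cl)c2)cc1` has not yet been measured. It differs from compound 1 in one place: 4-(tert-butyl)phenyl in place of ethyl on an aromatic carbon.

For the measured compounds named here, only one measured step speaks to this change. Going a 1.3-fold higher number from compound 1 to compound 2 (0.12 log units; within the scatter) put a 4-cyanophenyl in place of the same ethyl on the shared core, and the number stayed within the scatter. A phenyl ring at this spot therefore appears to be tolerated without a clear shift, though the tert-butyl group has no direct precedent among these compounds. The step of a 1.3-fold lower number from compound 1 to compound 4 (0.11 log units; within the scatter) is thus expected to stay small, with no confident direction. Compound 4 is estimated to give 2000 nM in this assay, within a range from 600 nM to 7000 nM.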

Compound 4, half-maximal effective concentration: 2400 nM
Estimate against measurement, compound 4: 1.2-fold (0.08 log units) below, and the stated range covers the measured number.
By their numbers in this assay, from the lowest: compound 3; then compounds 4, 1 and 2 (each within the scatter of the next).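

In this assay, for the compounds shown here, the earlier compounds offered only one aromatic group at this position, 4-cyanophenyl, and compound 4 now adds a second, giving a 1.1-fold lower number from compound 1 to compound 4 (0.03 log units; within the scatter) and staying within the scatter. The group carried on the phenyl ring also makes no readable difference here, since tert-butyl in place of cyano gives a 1.4-fold lower number from compound 2 to compound 4 (0.15 log units; within the scatter) and this too stays within the scatter. Ethyl, 4-cyanophenyl and 4-(tert-butyl)phenyl on the shared core therefore all give numbers that cannot be told apart, even though the entering groups differ widely in size and in what they carry.

On these data alone, whether an amine or a carboxylic acid on that phenyl ring, or a longer chain in place of ethyl, would move the number remains open. Nothing available explains why these numbers stay together.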